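Chloro for Methoxy on a Shared Core

The source may report more compounds than this note shows. Statements on the series, on what has been measured and on what is new or still open speak of the compounds shown alone.

Two compounds share one core and differ only in the groups on the outer ring. Compound 1 `Cc1cc(Cl)cc(-c2cc3cc(C(=N)N)ccc3[nH]2)c1` carries a methyl and a chloro group; in an assay on isolated protein for inhibition of acid-sensing ion channel 3 (Homo sapiens), read by patch clamp, tested at 1 uM (a higher number here means more inhibition at the concentration tested (going by the name of the read-out), a lower number less inhibition), compound 1 gives 87%. Compound 2 `COc1cc(F)cc(-c2cc3cc(C(=N)N)ccc3[nH]2)c1` carries a methoxy and a fluoro group; in this assay compound 2 gives 77%, a number that does not differ from compound 1 beyond the usual scatter. Compound 3 `N=C(N)c1ccc2[nH]c(-c3cc(F)cc(Cl)c3)cc2c1` changes compound 2 in one place: chloro in place of methoxy on an aromatic carbon. Going by the values given here, with no measured step to draw on, the expected step of a number 7 percentage points higher from compound 2 to compound 3 (within the scatter) is small and upward, likely within the scatter. Compound 3 is expected near 84%, with a range from 70% to 95%.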

Compound 3, a percentage reported as inhibition, at one concentration (the size of the read-out at that concentration, not a potency): 82%
For compound 3 the middle estimate is 2 percentage points above the measured one; low and high end bracket the measured number.
By their numbers in this assay, from the lowest: compounds 2, 3 and 1 (each within the scatter of the next).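

In this assay, chloro in place of methoxy gives a number 5 percentage points higher from compound 2 to compound 3 (within the scatter), so this position on the outer ring carries either group with readings that cannot be told apart. Fluoro in place of methyl gives a number 5 percentage points lower from compound 1 to compound 3 (within the scatter), so this second single change also cannot be told apart from the scatter. Nothing available here explains either step.

From the compounds shown here alone, whether an amine, a carboxylic acid or a longer chain at this position would read the same remains open. A reading at one concentration also leaves the potency of these compounds open.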